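The compounds below may be only part of what the source reports. "The series", "measured", "known", "first", "only" and "open" are said of these compounds alone.

In a functional assay on HL-60 cells (Homo sapiens) for inhibition, read by MTT assay, with a stated time of 72 h (a higher number here means a weaker inhibitor, a lower number a stronger inhibitor), compound 1 `Cc1nc(-c2ccccc2)c(C(=O)N2CCN(c3cccc(C(N)=O)c3)CC2)o1` gives 71 nM, and compound 2 `Cc1ccc(N2CCN(C(=O)c3oc(C)nc3-c3ccccc3)CC2)c(C)c1` gives 101 nM; the step of a 1.4-fold higher number from compound 1 to compound 2 (0.15 log units; within the scatter) is a small one. Compound 3 `CC(=O)c1ccc(N2CCN(C(=O)c3oc(C)nc3-c3ccccc3)CC2)cc1` stands apart: in this assay compound 3 gives "not active" (no number reported), and no number was given for it. Compound 4 `Cc1cc(C)cc(N2CCN(C(=O)c3oc(C)nc3-c3ccccc3)CC2)c1` differs from compound 3 in one place: 3,5-dimethylphenyl in place of 4-acetylphenyl on an amine nitrogen in a ring. Among the compounds with values here, no measured step covers this exact exchange, but the step from compound 1 to compound 2 shows that a dimethylphenyl group on that ring nitrogen supports inhibition at a level close to compound 1. Compound 4 is therefore expected to regain measurable inhibition, with an estimated value of 150 nM and a range from 40 nM to 1500 nM, though the lack of any number for compound 3 leaves this estimate uncertain.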

Compound 4, half-maximal inhibitory concentration: 34.5 nM
For compound 4 the middle estimate is 4.3-fold (0.64 log units) above the measured one; measured number outside the range, below it.
By their numbers in this assay, from the lowest: compound 4; then compounds 1 and 2 (each within the scatter of the next).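

In this assay, compound 3 has no number, so the exchange of 4-acetylphenyl for 3,5-dimethylphenyl cannot be sized, but it does link a "not active" report to a measured inhibitor. The arrangement of the two methyl groups matters modestly, with a 2.9-fold lower number from compound 2 to compound 4 (0.47 log units; beyond the scatter), and the 3,5-dimethylphenyl group also improves on 3-carbamoylphenyl, with a 2.1-fold lower number from compound 1 to compound 4 (0.31 log units; beyond the scatter). Nothing available explains these differences. Going by these compounds, it remains open whether the acetyl group itself accounts for the loss of activity in compound 3. A methoxy group, an amine or a carboxylic acid on this phenyl ring could also be informative.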